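This account rests on a few compounds, and the source may have more. Where it says the series, first, only, none or still open, it means among the compounds named here.

Measured compounds and their values:
- compound 1, `CCCc1cc(N)c2cc(NC(=O)/C=C/c3ccc(O)cc3)ccc2n1`, in an assay on isolated protein for displacement of a labelled ligand from melanin-concentrating hormone receptor 1 (Homo sapiens); a lower number here means a stronger inhibitor, a higher number a weaker inhibitor: 1100 nM
- compound 2, `CCCc1cc(N)c2cc(NC(=O)/C=C/c3ccc(N)cc3)ccc2n1`, in this assay: 190 nM
- compound 3, `CCCc1cc(N)c2cc(NC(=O)/C=C/c3ccc(C(C)(C)C)cc3)ccc2n1`, in this assay: 22 nM

Compound 3 carries the lowest number of the three; compound 2 sits nearest, an 8.6-fold lower number from compound 2 to compound 3 (0.94 log units; beyond the scatter), and compound 1 furthest, a 50-fold lower number from compound 1 to compound 3 (1.70 log units; beyond the scatter), so compound 3 is the strongest inhibitor among the measured compounds.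

Compound 4, `CCCc1cc(N)c2cc(NC(=O)/C=C/c3ccc(C(C)C)cc3)ccc2n1`, differs from compound 3 in one place: hydrogen in place of methyl on a saturated chain carbon bound to an aromatic carbon and two saturated chain carbons.

Among the compounds with values here, none of the measured steps changes the same group. The steps seen here all exchange the substituent on the aromatic carbon outright, the amino step a 5.8-fold lower number from compound 1 to compound 2 (0.76 log units; beyond the scatter) and the two tert-butyl steps a 50-fold lower number from compound 1 to compound 3 (1.70 log units; beyond the scatter) and an 8.6-fold lower number from compound 2 to compound 3 (0.94 log units; beyond the scatter), and all three point towards a lower number as the group grows from hydroxy to amino to tert-butyl. Trimming tert-butyl to isopropyl cuts the same group back by one methyl, so a step in the opposite direction seems plausible, but a small one, since the group stays closer to tert-butyl than to amino.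

Compound 4 is therefore expected to give 40 nM in this assay, with a likely range of 15 nM to 120 nM, which amounts to an expected 1.8-fold higher number from compound 3 to compound 4 (0.26 log units; within the scatter).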

Compound 4, half-maximal inhibitory concentration: 2.9 nM
Beside the measured number, compound 4's estimate is 14-fold (1.14 log units) above it, and the stated range ends above it.
By their numbers in this assay, from the lowest: compound 4; then compound 3; then compound 2; then compound 1.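

In this assay, tert-butyl is not the limit at this aromatic substituent: removing a single methyl from the saturated chain carbon, so that tert-butyl becomes isopropyl, gives a further gain in the same direction (a 7.6-fold lower number from compound 3 to compound 4 (0.88 log units; beyond the scatter)), beyond the scatter. The earlier compounds shown here could be read as a larger group giving a lower number, but compound 4 goes against that reading, since isopropyl also stands well ahead of the amino group (a 66-fold lower number from compound 2 to compound 4 (1.82 log units; beyond the scatter)) and the hydroxy group (a 380-fold lower number from compound 1 to compound 4 (2.58 log units; beyond the scatter)) and yet carries one methyl fewer than tert-butyl, so the number at this position does not simply follow the size of the group. Nothing available here accounts for why one methyl fewer has this result.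

The compounds shown leave open whether cutting the group further, to ethyl or methyl, would lower the number again or raise it, and whether a cyclopropyl ring or a chlorine atom on the same aromatic carbon would match isopropyl. They also leave open whether the tert-butyl to isopropyl exchange would give a step of this size if the propyl chain on the shared core were replaced by another group.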